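A few compounds are considered here, and "the series" means these few. Any claim that something is new, unique, unknown or untested is made for them only; others in the source may bear on it.

Measured in a functional assay on BaF3 cells (Mus musculus) for antiproliferative activity; on this read-out higher numbers stand for an effect only at larger amounts of compound and lower numbers for an effect already at smaller amounts:
- compound 1 `CCN1CCN(Cc2ccc(NC(=O)c3ccc(C)c(C#Cc4cnccn4)c3)cc2C(F)(F)F)CC1`: 2490 nM
- compound 2 `CCN1CCN(Cc2ccc(NC(=O)c3ccc(C)c(C#Cc4cnc(N)cn4)c3)cc2C(F)(F)F)CC1`: 860 nM
- compound 3 `CCN1CCN(Cc2ccc(NC(=O)c3ccc(C)c(C#Cc4cnc5[nH]cnc5c4)c3)cc2C(F)(F)F)CC1`: 60 nM

Of these three, compound 3 has the lowest number, 60 nM, so it acts at the smallest amount. Compound 4 `CCN1CCN(Cc2ccc(NC(=O)c3ccc(C)c(C#Cc4coc5ccccc45)c3)cc2C(F)(F)F)CC1` keeps the shared core but swaps the group on a triple-bonded carbon: a group of 9 heavy atoms (8 carbon, 1 oxygen; one five-membered aromatic ring with 1 hetero atom, one six-membered aromatic ring of carbon only) in place of a group of 9 heavy atoms (6 carbon, 3 nitrogen; one five-membered aromatic ring with 2 hetero atoms, one six-membered aromatic ring with 1 hetero atom), on a triple-bonded carbon. The incoming 1-benzofuran-3-yl also has two rings, but it contains only carbon and oxygen.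

Among the compounds with values here, three measured steps bear on this change. The largest are a 42-fold lower number from compound 1 to compound 3 (1.62 log units; beyond the scatter) and a 14-fold lower number from compound 2 to compound 3 (1.16 log units; beyond the scatter), while a 2.9-fold lower number from compound 1 to compound 2 (0.46 log units; beyond the scatter) is modest. The two large steps alter ring make-up and hetero atoms together, so they cannot show which feature matters. Within the data shown here, no measured compound lacks a ring nitrogen in this group, which makes any forecast uncertain. Some of the gain seen for compound 3 is expected to be lost while the two-ring shape is kept. The expected change is a 13-fold higher number from compound 3 to compound 4 (1.12 log units; beyond the scatter), a large step towards a higher number. For compound 4 the estimated value is 800 nM, with an expected range of 120 nM to 5000 nM.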

Compound 4, half-maximal effective concentration: 6760 nM
Beside the measured number, compound 4's estimate is 8.5-fold (0.93 log units) below it, outside the stated range (above it).
By their numbers in this assay, from the lowest: compound 3; then compound 2; then compound 1; then compound 4.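

In this assay, a two-ring group at this triple-bonded carbon does not by itself give a low number: 1-benzofuran-3-yl in place of the nitrogen-containing two-ring group gives a 110-fold higher number from compound 3 to compound 4 (2.05 log units; beyond the scatter), even though both groups have the same ring sizes and heavy-atom count. The new group also compares poorly with the one-ring groups, with a 7.9-fold higher number from compound 2 to compound 4 (0.90 log units; beyond the scatter) and a 2.7-fold higher number from compound 1 to compound 4 (0.43 log units; beyond the scatter), so here the two-ring shape without ring nitrogen gives the highest number of the four compounds. No supporting measurement is available to explain this result.

Ring nitrogens, ring oxygen and the hydrogen-bond donor all change together from compound 3 to compound 4, so their separate contributions remain open. From the compounds shown here alone, it also remains open how a two-ring group would behave with a single ring nitrogen, as in quinolin-3-yl, or with an amine on the 1-benzofuran-3-yl.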